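The source may report more compounds than this note shows. Statements on the series, on what has been measured and on what is new or still open speak of the compounds shown alone.

In a functional assay on HepG2 cells (Homo sapiens) for antiproliferative activity, read by MTT assay, with a stated time of 72 h (on this read-out lower numbers stand for stronger inhibition and higher numbers for weaker inhibition), compound 2 (`COc1cccc(N2C(=O)COc3ccc(-c4cnc(OC)c(NS(=O)(=O)c5ccc(F)cc5)c4)cc32)c1`) gives only a limit, > 40000 nM, and not a number. Compound 1 (`COc1cccc(N2C(=O)COc3ccc(-c4cnc(Cl)c(NS(=O)(=O)c5ccc(F)cc5)c4)cc32)c1`) likewise gives a limit, > 40000 nM. Compound 3 (`O=C1COc2ccc(-c3cnc(Cl)c(NS(=O)(=O)c4ccc(F)cc4)c3)cc2N1`) also gives a limit, > 40000 nM. The evidence across the series is the limit of > 40000 nM in this assay, at which 3 of the 3 values shown sit. Within the data shown here, neither a step that the two limits leave unreadable from compound 1 to compound 2 nor a step that the two limits leave unreadable from compound 1 to compound 3 has a readable size, so no measured step sets a size for compound 4 (`COc1ccc(N2C(=O)COc3ccc(-c4cnc(OC)c(NS(=O)(=O)c5ccc(F)cc5)c4)cc32)cc1`). The change is 4-methoxyphenyl in place of 3-methoxyphenyl on an amide-type nitrogen in a ring. No shift beyond the scatter is expected in this assay, and another limit is the likeliest result. The expected step is a number no higher from compound 2 to compound 4 (the limit leaves the size open). The estimate for compound 4 is 40000 nM, with an expected range of 15000 nM to 80000 nM.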

Compound 4, half-maximal inhibitory concentration: 13100 nM
Beside the measured number, compound 4's estimate is 3.1-fold (0.48 log units) above it; the measured number lies below the stated range.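

In this assay, 4-methoxyphenyl in place of 3-methoxyphenyl on the amide-type nitrogen in a ring gives an at least 3.0-fold lower number from compound 2 to compound 4 (0.48 log units; beyond the scatter). Among these compounds, the two groups hold the same atoms, so the place of the methoxy on the phenyl ring alone separates compound 4 from the value shared by the other compounds: the limit of > 40000 nM in this assay, at which 3 of the 4 values shown sit. The steps among compound 1, compound 2 and compound 3 cannot be read, which leaves this as the only sized change.

As far as these compounds go, whether 4-methoxyphenyl gives a number with chloro in place of the core methoxy stays open. So does the effect of an amine or a carboxylic acid on that phenyl ring.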